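The compounds below may be only part of what the source reports. "The series", "measured", "known", "first", "only" and "open" are said of these compounds alone.

Compound 1 `CCNC(=O)c1noc(-c2cc(C(C)C)c(O)cc2O)c1-c1cc(CNCCO)no1`: 111 nM
Compound 2 `CCNC(=O)c1noc(-c2cc(C(C)C)c(O)cc2O)c1-c1cc(CN(CC)CC)no1`: 38 nM
Compound 3 `CCNC(=O)c1noc(-c2cc(C(C)C)c(O)cc2O)c1-c1cc(CN2CCN(C)CC2)no1`: 340 nM

These three compounds share one core and were all tested in a functional assay on HCT-116 cells (Homo sapiens) for inhibition; a higher number here means a weaker inhibitor, a lower number a stronger inhibitor. On the numbers shown, compound 1 stands second highest of the three: compound 2 lies nearest, reached by a 2.9-fold lower number from compound 1 to compound 2 (0.47 log units; beyond the scatter), and compound 3 lies furthest, reached by a 3.1-fold higher number from compound 1 to compound 3 (0.49 log units; beyond the scatter). Between the other two, an 8.9-fold higher number from compound 2 to compound 3 (0.95 log units; beyond the scatter). Every one of these measured steps changes only the group on the saturated chain carbon bound to an aromatic carbon.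

Compound 4 `CCNC(=O)c1noc(-c2cc(C(C)C)c(O)cc2O)c1-c1ccn(CC)n1` is not yet measured. Its change from compound 1 is: 1-ethyl-1H-pyrazol-3-yl in place of 3-(((2-hydroxyethyl)amino)methyl)-1,2-oxazol-5-yl on an aromatic carbon. This is a change of a different kind: the whole ring together with its chain is exchanged, not only the group on the chain, so none of the three measured steps bears on it directly. Going by the values given here, they show only that changes on this side of the core moved this assay by modest amounts in both directions. With no closer guide, the expected step is a 1.4-fold higher number from compound 1 to compound 4 (0.13 log units; within the scatter), small and uncertain in direction, inside a wide range. Compound 4 is therefore estimated at 150 nM, between 40 nM and 600 nM.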

Compound 4, half-maximal inhibitory concentration: 25 nM
Compound 4: the middle estimate sits 6.0-fold (0.78 log units) above what was measured; measured number outside the range, below it.
By their numbers in this assay, from the lowest: compounds 4 and 2 (each within the scatter of the next); then compound 1; then compound 3.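

In this assay, putting 1-ethyl-1H-pyrazol-3-yl in place of 3-(((2-hydroxyethyl)amino)methyl)-1,2-oxazol-5-yl gives a 4.4-fold lower number from compound 1 to compound 4 (0.65 log units; beyond the scatter), so the amine-bearing chain that all three earlier compounds carry is not required for activity at this aromatic carbon, and the entering group does this with fewer heavy atoms and no hydrogen-bond donors. Compound 2 at 38 nM and compound 4 at 25 nM lie within the usual scatter of each other, which means a ring with only a small ethyl group reaches the same level as the diethylamino compound, the one with the lowest number among the amines shown. Nothing measured here explains why this change moves the number in this direction.

This step exchanges the ring and removes the chain at once, so the compounds shown cannot separate the effect of the ring from the effect of losing the amine; a 1,2-oxazol-5-yl group carrying only a methyl, or the same pyrazole carrying a diethylaminomethyl chain, would pull the two apart. From the compounds shown here alone, how far the ethyl group on the pyrazole nitrogen can change also stays open, for example to a longer propyl or butyl chain or to a chain ending in a carboxylic acid.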